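The source may report more compounds than this note shows. Statements on the series, on what has been measured and on what is new or still open speak of the compounds shown alone.

Compound 1, `COc1ccc(/C=C/C(=O)/C=C/c2ccc(OCc3cn(CCCCOc4cc(=O)oc5ccccc45)nn3)c(OC)c2)cc1OC`: in a functional assay on COLO 205 cells (Homo sapiens) for inhibition, read by sulforhodamine B assay, with a stated time of 48 h, tested at 50 uM (on this read-out lower numbers stand for less inhibition of growth and higher numbers for more inhibition of growth at the one concentration tested), compound 1 gives 53%.
Compound 2, `COc1cccc(/C=C/C(=O)/C=C/c2ccc(OCc3cn(CCCCOc4cc(=O)oc5ccccc45)nn3)c(OC)c2)c1`: compound 2 gives 46%.
Compound 3, `COc1cc(/C=C/C(=O)/C=C/c2cc(OC)c(OC)c(OC)c2)ccc1OCc1cn(CCOc2cc(=O)oc3ccccc23)nn1`: compound 3 gives 86%.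

Compound 4, `COc1ccc(/C=C/C(=O)/C=C/c2ccc(OCc3cn(CCOc4cc(=O)oc5ccccc45)nn3)c(OC)c2)cc1OC`, has not yet been measured. It arises from compound 3 by the change (hydrogen in place of methoxy on an aromatic carbon). The same kind of change has already been measured once, from compound 1 to compound 2, where hydrogen in place of methoxy on an aromatic carbon gave a number 7 percentage points lower from compound 1 to compound 2 (within the scatter). The surroundings of the place are not identical: in the first pair the carbon is para to a large group, whereas in the second it is meta to a large group and meta to a methoxy group. The difference between the two cores of compound 1 and compound 3 is not broken down here. Compound 3 stands highest of the three measured compounds, well beyond the scatter from the other two. Because the earlier step of a number 7 percentage points lower from compound 1 to compound 2 (within the scatter) was small, a small step is expected here too, namely a number 10 percentage points lower from compound 3 to compound 4 (within the scatter) in this assay. Compound 4 is therefore estimated at 76%, between 58% and 90%.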

Compound 4, percent growth inhibition at one concentration: 80%
The estimate for compound 4 lay 4 percentage points below the measured number, within the range that was stated.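

In this assay, replacing a methoxy group with hydrogen, which turns 3,4,5-trimethoxyphenyl into 3,4-dimethoxyphenyl, gives a number 6 percentage points lower from compound 3 to compound 4 (within the scatter). The same swap has now been read on two different cores, and the two readings agree: the same change on two cores in this assay, a number 7 percentage points lower (within the scatter) from compound 1 to compound 2 and a number 6 percentage points lower (within the scatter) from compound 3 to compound 4, 1 percentage points apart, within the scatter of two such steps. Going by these compounds alone, this suggests that, within these two pairs, the swap can be carried from one core to the other without a visible shift in the number, but it rests on only two pairs, one cell line and one concentration, and since each step lies within the scatter, it does not show that this methoxy group has any real effect or that the agreement would hold on a further core.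

The compounds shown leave open what a group other than hydrogen or methoxy, such as an amine or a carboxylic acid, would do at this place on the aromatic ring. They also leave open how a hexyl chain would fare in the link to the triazole.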